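Triazole amides: ester-for-benzyl change at the triazole nitrogen

This account rests on a few compounds, and the source may have more. Where it says the series, first, only, none or still open, it means among the compounds named here.

Compound 1 `C#Cc1ccc(NC(=O)c2cn(Cc3ccccc3)nn2)cc1` and compound 2 `C#Cc1ccc(NC(=O)c2cn(CC(=O)OCC)nn2)cc1` share one core; compound 3 `O=C(NCc1cn(Cc2ccccc2)nn1)c1cn(Cc2ccccc2)nn1` and compound 4 `CCOC(=O)Cn1cc(CNC(=O)c2cn(Cc3ccccc3)nn2)nn1` share another, and the difference between the two cores is not broken down here. In a functional assay on B16 cells (Mus musculus) for cytotoxicity, read by MTT assay, with a stated time of 48 h (a higher number here means a weaker inhibitor, a lower number a stronger inhibitor), compound 1 gives only a limit, > 100000 nM. Compound 2 likewise gives only a limit, > 100000 nM. The change between them, (ethoxycarbonyl in place of phenyl on a saturated chain carbon bound to an aromatic nitrogen), thus yields a step that the two limits leave unreadable from compound 1 to compound 2; here the limit of > 100000 nM in this assay, at which 2 of the 3 values shown sit, governs what can be read. Within the data shown here, compound 3 gives 300 nM in this assay, the only number in the set. The same change, (ethoxycarbonyl in place of phenyl on a saturated chain carbon bound to an aromatic nitrogen), carries compound 3 to compound 4. Among the measured compounds shown here, the measured pair gives no size for this step, so the expectation rests on compound 3 alone, at 300 nM, with a wide band. Compound 4 is expected to give 1000 nM in this assay, between 200 nM and 10000 nM. The step of a 3.3-fold higher number from compound 3 to compound 4 (0.52 log units; beyond the scatter) is therefore an estimate only.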

Compound 4, half-maximal inhibitory concentration: 35000 nM
Estimate against measurement, compound 4: 35-fold (1.54 log units) below; measured number above the stated range.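

On the core of compound 3, ethoxycarbonyl in place of phenyl on a saturated chain carbon bound to an aromatic nitrogen gives, in this assay, a 120-fold higher number from compound 3 to compound 4 (2.07 log units; beyond the scatter). This single pair shows that the change can have a large effect on that core, but it does not show that the effect carries over from the core of compound 1, where the same step cannot be read. The comparison between cores stops at an assay limit: the limit of > 100000 nM in this assay, at which 2 of the 4 values shown sit.

Still open, on these data alone, is how a carboxylic acid or an amine in place of ethoxycarbonyl at that carbon would read on the core of compound 3. Also open, as far as these compounds go, is whether a longer chain there would keep the number of compound 4 or move it.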